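Isopropyl for bromo on a weak thiazole-amine inhibitor

The source may report more compounds than this note shows. Statements on the series, on what has been measured and on what is new or still open speak of the compounds shown alone.

Measured compounds:
Compound 1, `Brc1cccc(Nc2nc(-c3ccncc3)cs2)c1`, gives 40700 nM in a functional assay on RCC4 cells (Homo sapiens) for inhibition, read by XTT assay, with a stated time of 4 days; a higher number here means a weaker inhibitor, a lower number a stronger inhibitor.
Compound 2, `Cc1cccc(Nc2nc(-c3ccncc3Br)cs2)c1`, gives 3980 nM in this assay.
Compound 3, `Cc1cccc(Nc2nc(-c3ccncc3)c(C(=O)N(C)C)s2)c1`, gives 16200 nM in this assay.

Compound 1 has the highest number of the three and is therefore the weakest inhibitor in this small set; compound 3 sits nearer to it, and compound 2 sits furthest away, both beyond the usual scatter. Among the compounds with values here, the three compounds share a core and differ at more than one place, so no single-point step between measured compounds is available.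

Compound 4, `CC(C)c1cccc(Nc2nc(-c3ccncc3)cs2)c1`, is not yet measured. It differs from compound 1 in one place: isopropyl in place of bromo on an aromatic carbon. Within the data shown here, no measured pair shows what this exchange does here, so the expectation rests on compound 1 alone, whose value 40700 nM is the starting point. A small change is expected, towards a lower number, in the step of a 1.6-fold lower number from compound 1 to compound 4 (0.21 log units; within the scatter), but not clearly beyond the scatter. For compound 4 the estimate is 25000 nM, with a range from 8000 nM to 80000 nM.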

Compound 4, half-maximal inhibitory concentration: 17400 nM
The estimate for compound 4 lay 1.4-fold (0.16 log units) above the measured number; low and high end bracket the measured number.
By their numbers in this assay, from the lowest: compound 2; then compounds 3 and 4 (each within the scatter of the next); then compound 1.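

In this assay, within the data shown here, the exchange of bromo for isopropyl, on an aromatic carbon meta to a large group, gives a 2.3-fold lower number from compound 1 to compound 4 (0.37 log units; beyond the scatter) and supplies the first comparison in this set that changes one place only. This position therefore takes a branched group of three carbons in place of a single bromine, and the number falls modestly rather than rises. The data offer no measured explanation for this step.

From the compounds shown here alone, it stays open whether a lower number would also come with a group of another kind on this carbon, such as an amine or a carboxylic acid, or with a longer chain. The compounds shown also leave open whether the same exchange would give a similar step on a core changed elsewhere, as in compound 2 or compound 3.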